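This account rests on a few compounds, and the source may have more. Where it says the series, first, only, none or still open, it means among the compounds named here.

Measured in an ADME assay on MT4 cells (Homo sapiens) for cytotoxicity; a lower number here means that less compound is tolerated, a higher number that more compound is tolerated:
- Compound 1 `CCNC(=S)Nc1cccc(C(F)(F)F)c1`: > 100000 nM
- Compound 2 `FC(F)(F)c1cccc(NC(=S)Nc2cccc(Br)c2)c1`: 9200 nM

Compound 1 gives > 100000 nM, which is a limit of the assay. Within the data shown here, compound 2, at 9200 nM, therefore holds the only actual number in this assay. Compound 3 `CSCCCNC(=S)Nc1cccc(C(F)(F)F)c1` carries 3-(methylsulfanyl)propyl in place of 3-bromophenyl on an amide-type nitrogen.

Among the measured compounds shown here, only one measured step bears on this change: an at least 10-fold lower number from compound 1 to compound 2 (1.03 log units; beyond the scatter). That large step brought in 3-bromophenyl in place of ethyl. Compound 3 gives up the same 3-bromophenyl for a group with no ring, so most of the step of an at least 10-fold lower number from compound 1 to compound 2 (1.03 log units; beyond the scatter) is expected to be reversed, although this rests on a single step. The expected step is a 6.5-fold higher number from compound 2 to compound 3 (0.81 log units; beyond the scatter), towards a higher number and beyond the scatter. For compound 3 the estimate is 60000 nM, with an expected range of 20000 nM to 100000 nM. A report of only a limit would be no surprise.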

Compound 3, half-maximal cytotoxic concentration: 43000 nM
For compound 3 the middle estimate is 1.4-fold (0.14 log units) above the measured one, and the stated range covers the measured number.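

Exchanging 3-bromophenyl for 3-(methylsulfanyl)propyl on the amide-type nitrogen gives a 4.7-fold higher number from compound 2 to compound 3 (0.67 log units; beyond the scatter) in this assay and shows that a much higher tolerated concentration can be kept with a chain that has no ring. The chain still counts for something, with an at least 2.3-fold lower number from compound 1 to compound 3 (0.36 log units; beyond the scatter) as the step for (methylsulfanyl)methyl in place of hydrogen on the saturated chain carbon, so compound 3 lies between compound 2 and compound 1 in this assay. Compound 1 stands only as a limit, so the full size of that step stays unknown: the limit of > 100000 nM in this assay, at which 1 of the 3 values shown sits.

Open, going by these compounds, is whether the sulfur or the chain itself sets the value of compound 3, which a plain butyl chain or a propyl chain ending in a hydroxyl group would help separate. Open too, on these data alone, is whether the bromine or the phenyl ring matters in compound 2, a question for an unsubstituted phenyl group.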